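A small change at the dimethylamino group

The source may hold more compounds than are shown below. What is called first, only, known or untested is meant among the compounds shown, and "the series" means these compounds.

Measured in an ADME assay on L6 cells (Rattus norvegicus) for cytotoxicity, with a stated time of 72 h; on this read-out lower numbers stand for stronger inhibition and higher numbers for weaker inhibition:
Compound 1 `CC(=O)OC1CC2(N(C)C)CC(c3ccccc3)C1C(c1ccccc1)C2`: "not determined" (no result reported)
Compound 2 `CN(C)C12CC(OC(=O)CN3CCCC3)C(C(c3ccccc3)C1)C(c1ccccc1)C2`: 32700 nM
Compound 3 `CN(C)C12CC(O)C(C(c3ccccc3)C1)C(c1ccccc1)C2`: 133000 nM

Only two of these compounds have a number, and compound 2 holds the lower one at 32700 nM, which on this read-out means stronger inhibition of the cells. Compound 1 offers no number to compare.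

The next compound to be tested is compound 4 `O=C(CN1CCCC1)OC1CC2(N3CCCC3)CC(c3ccccc3)C1C(c1ccccc1)C2`. It keeps the shared core and the ester side chain of compound 2, but carries pyrrolidin-1-yl in place of dimethylamino on a saturated ring carbon.

Within the data shown here, only one measured step is available as a guide, a 4.1-fold higher number from compound 2 to compound 3 (0.61 log units; beyond the scatter). That step removes ((pyrrolidin-1-yl)methyl)carbonyl from an oxygen, so it concerns a different place in the molecule and is a larger edit. It gives a modest yardstick for size and says nothing directly about this swap. Among the measured compounds shown here, no measured compound changes the dimethylamino group itself.

With so limited a change, little movement is expected in this assay. The estimated step, a 1.3-fold lower number from compound 2 to compound 4 (0.10 log units; within the scatter), is expected to stay within the usual scatter, so no clear direction is predicted. For compound 4 the estimated value is 26000 nM, with an expected range from 11000 nM to 60000 nM.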

Compound 4, half-maximal inhibitory concentration: 42900 nM
For compound 4 the middle estimate is 1.7-fold (0.22 log units) below the measured one; low and high end bracket the measured number.
By their numbers in this assay, from the lowest: compounds 2 and 4 (each within the scatter of the next); then compound 3.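

Among these compounds, this is the first measured step at the amine on the saturated ring carbon itself: in this assay, pyrrolidin-1-yl in place of dimethylamino gives a 1.3-fold higher number from compound 2 to compound 4 (0.12 log units; within the scatter). The incoming group has 5 heavy atoms instead of 3 and adds one five-membered non-aromatic ring, yet the two compounds cannot be told apart on this read-out, so at this position, with this ester side chain in place, closing the amine's two carbon arms into a ring shows no measurable effect on the number. Nothing available explains this outcome.

On these data alone, whether this position would stay as unresponsive with a larger change, such as piperidin-1-yl or a primary amine, remains open. Among the compounds shown here, it is also open whether the same swap would give a similar result in a compound carrying a free hydroxyl group like that of compound 3 instead of the (((pyrrolidin-1-yl)methyl)carbonyl)oxy group, since the only measured step at this position has that ester in place.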